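Replacing the benzyl of compound 1 with isopropyl

A few compounds are considered here, and "the series" means these few. Any claim that something is new, unique, unknown or untested is made for them only; others in the source may bear on it.

Measured compounds:
compound 1 `Cc1nn(-c2ncnc3nc[nH]c23)c2c1C(OCCc1ccccc1)CC(=O)N2`: 40 nM
compound 2 `Cc1nn(-c2ncnc3nc[nH]c23)c2c1C(c1ccc(F)cc1Cl)CC(=O)N2`: 280 nM
compound 3 `Cc1nn(-c2ncnc3nc[nH]c23)c2c1C(OCc1ccc(Cl)cc1Cl)CC(=O)N2`: 243 nM

All three compounds share one core and were tested in a functional assay on HEK293 cells for agonist activity at G-protein coupled receptor 39 (Homo sapiens), read by scintillation proximity assay and inositol phosphate accumulation, with a stated time of 75 min; a lower number here means that less compound is needed, a higher number that more compound is needed for the effect. Compound 1 stands lowest of the three numbers, so it needs the least compound for the effect. Changing its side group cost in both measured cases: a 7.0-fold higher number from compound 1 to compound 2 (0.85 log units; beyond the scatter), and a 6.1-fold higher number from compound 1 to compound 3 (0.78 log units; beyond the scatter). Between the two altered compounds the gap is small, a 1.2-fold lower number from compound 2 to compound 3 (0.06 log units; within the scatter), so those two cannot be ordered.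

Compound 4 `Cc1nn(-c2ncnc3nc[nH]c23)c2c1C(OCC(C)C)CC(=O)N2` differs from compound 1 in one place: isopropyl in place of benzyl on a saturated chain carbon bound to an oxygen on a saturated carbon. The change keeps the oxygen and the chain but removes the six-membered aromatic ring of carbon only and puts a smaller, ring-free group in its place.

Within the data shown here, no measured step trades the ring for a group without a ring, so none bears directly on this change. What the two steps away from compound 1 show is that each alteration of the side group raised the number in this assay by a modest amount. On that basis a modest rise is expected for compound 4 as well, a 3.3-fold higher number from compound 1 to compound 4 (0.51 log units; beyond the scatter), with wide uncertainty in both directions. Compound 4 is therefore expected to give about 130 nM in this assay, within a range from 40 nM to 450 nM.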

Compound 4, half-maximal effective concentration: 111 nM
Beside the measured number, compound 4's estimate is 1.2-fold (0.07 log units) above it; the range from low to high includes it.
By their numbers in this assay, from the lowest: compound 1; then compound 4; then compounds 3 and 2 (each within the scatter of the next).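

In this assay the benzyl at this position can give way to the ring-free isopropyl at a modest cost (a 2.8-fold higher number from compound 1 to compound 4 (0.44 log units; beyond the scatter)), so the aromatic ring of compound 1 is not needed for activity in this series. The ring-free group also gives a lower number than either chlorine-bearing aromatic side group (a 2.2-fold lower number from compound 3 to compound 4 (0.34 log units; beyond the scatter); a 2.5-fold lower number from compound 2 to compound 4 (0.40 log units; beyond the scatter)), so having an aromatic ring in the side group does not by itself give a low number: compound 1 has such a ring and stands lowest, while compounds 2 and 3 have one and stand highest. No measurement is available to explain these differences.

The compounds shown leave open whether the gap to compound 1 comes from the aromatic ring itself or simply from the size of the group, which a cyclohexyl group in place of the benzyl could help separate. They also leave open how a longer chain without a ring, or an amine or a carboxylic acid at the end of the chain, would behave at this position.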